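Replacing the side-chain ring of compound 1

The source may report more compounds than this note shows. Statements on the series, on what has been measured and on what is new or still open speak of the compounds shown alone.

Within the data shown here, in a functional assay on A549 cells (Homo sapiens) for cytotoxicity, read by MTT assay, with a stated time of 72 h (a lower number here means a stronger inhibitor, a higher number a weaker inhibitor), compound 1 (`O=C1c2c[n+]([O-])c3ccccc3c2C(=O)c2c1c1ccccc1n2Cc1cn([C@H]2O[C@H](CO)[C@@H](O)[C@H]2O)nn1`) gives 2680 nM as its half-maximal inhibitory concentration, the highest of the three numbers so far, which makes it the weakest inhibitor of the three. Compound 2 (`O=C1c2c[n+]([O-])c3ccccc3c2C(=O)c2c1c1ccccc1n2CCCCn1ccnc1`) gives 170 nM and compound 3 (`O=C1c2c[n+]([O-])c3ccccc3c2C(=O)c2c1c1ccccc1n2CCN1CCCC1`) gives 410 nM on the same scale. Compound 4 (`CC1(C)O[C@@H](CO)[C@H](Cn2cc(Cn3c4c(c5ccccc53)C(=O)c3c[n+]([O-])c5ccccc5c3C4=O)nn2)O1`) awaits measurement and carries one change from compound 1 ((5-(hydroxymethyl)-2,2-dimethyl-1,3-dioxolan-4-yl)methyl in place of 3,4-dihydroxy-5-(hydroxymethyl)oxolan-2-yl on an aromatic nitrogen) on an aromatic nitrogen of a five-membered aromatic ring with 3 nitrogen. Among the measured compounds shown here, the one measured step (a 2.4-fold higher number from compound 2 to compound 3 (0.38 log units; beyond the scatter)) is modest and sits on a different side chain, so it offers only a rough size for a swap like this. For the measured compounds named here, no measured pair tests this swap directly. Compound 1 at 2680 nM carries the departing 3,4-dihydroxy-5-(hydroxymethyl)oxolan-2-yl group, while compound 2 at 170 nM and compound 3 at 410 nM lack it and give the lower numbers, and compound 4 loses that group too. The expected change (a 2.4-fold lower number from compound 1 to compound 4 (0.39 log units; beyond the scatter)) is therefore a modest one toward a lower number. Compound 4 is estimated at 1100 nM with a range from 350 nM to 3200 nM as the expected span.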

Compound 4, half-maximal inhibitory concentration: 370 nM
The estimate for compound 4 lay 3.0-fold (0.47 log units) above the measured number, and the stated range covers the measured number.
By their numbers in this assay, from the lowest: compound 2; then compounds 4 and 3 (each within the scatter of the next); then compound 1.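

In this assay, among these compounds, the side-chain ring on the aromatic nitrogen of the five-membered aromatic ring with 3 nitrogen is exchanged in a single step, giving a 7.2-fold lower number from compound 1 to compound 4 (0.86 log units; beyond the scatter), so the number responds to the group at this position, something the earlier compounds could not show. The swap changes the ring, the hydrogen-bond donors and acceptors, and the defined stereocentres all at once, so this one step cannot separate their contributions. No measurement shown here explains the change.

As far as these compounds go, it remains open whether a single change to the ring in compound 4, such as freeing its protected hydroxyl groups, would move the number. From the compounds shown here alone, how an amine, a carboxylic acid or a longer carbon chain would behave on this same aromatic nitrogen also remains open.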